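Series notes: terminal aryl swap on the urea of compound 1

The compounds below may be only part of what the source reports. "The series", "measured", "known", "first", "only" and "open" are said of these compounds alone.

In a functional assay on MDA-MB-231 cells (Homo sapiens) for inhibition, read by sulforhodamine B assay, with a stated time of 48 h (a lower number here means a stronger inhibitor of growth, a higher number a weaker inhibitor of growth), compound 1 `O=C(Nc1cccc(-n2cc(-c3ccncc3)c(-c3ccc(Cl)c(O)c3)n2)c1)Nc1ccc(Cl)c(Cl)c1` gives 8330 nM, the lowest of the two numbers in hand; the nearest is compound 3 `COc1cc(-c2nn(-c3cccc(NC(=O)c4ccccc4)c3)cc2-c2ccncc2)ccc1Cl` at 13700 nM, and that gap lies within the scatter. Compound 2 `COc1cc(-c2nn(-c3cccc(NC(=O)c4ccc(Cl)c(C(F)(F)F)c4)c3)cc2-c2ccncc2)ccc1Cl` reaches only the limit > 32500 nM, and (the limit of > 32500 nM in this assay, at which 1 of the 3 values shown sits). Among the measured compounds shown here, the one measured step, an at least 2.3-fold lower number from compound 2 to compound 3 (0.37 log units; beyond the scatter), shows removal of substituents from the terminal aryl of an amide giving a lower number, at least modestly. Compound 4 `O=C(Nc1cccc(-n2cc(-c3ccncc3)c(-c3ccc(Cl)c(O)c3)n2)c1)Nc1cccc(C(F)(F)F)c1` differs from compound 1 by 3-(trifluoromethyl)phenyl in place of 3,4-dichlorophenyl on an amide-type nitrogen. That step is on a urea rather than an amide, so the measured step bears only loosely; a small move in this assay, if any, is expected. For compound 4 the estimate is 7000 nM (range 3000 nM to 18000 nM), a step of a 1.2-fold lower number from compound 1 to compound 4 (0.08 log units; within the scatter) that is expected to stay within the scatter.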

Compound 4, concentration for total growth inhibition: 26800 nM
Compound 4: middle estimate off by 3.8-fold (0.58 log units), on the low side, outside the stated range (above it).
By their numbers in this assay, from the lowest: compounds 1, 3 and 4 (each within the scatter of the next, the first and the last beyond it). At a limit, above all of these: compound 2.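

In this assay, 3-(trifluoromethyl)phenyl in place of 3,4-dichlorophenyl on an amide-type nitrogen gives a 3.2-fold higher number from compound 1 to compound 4 (0.51 log units; beyond the scatter), so the terminal aryl of the urea is a position that responds to substitution. The earlier step, from compound 2 to compound 3, showed such a response only on an amide. Nothing in hand points to a cause for this step. Still open, going by these compounds, is how the urea series responds to a terminal aryl carrying a methoxy group, a dimethylamino group or a carboxylic acid.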